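This account rests on a few compounds, and the source may have more. Where it says the series, first, only, none or still open, it means among the compounds named here.

Measured compounds:
- compound 1 `O=C(Nn1c(CCC2CCCC2)nc2c(-c3ccc(Cl)cc3)n[nH]c2c1=O)c1ccccc1`: 87.3%
- compound 2 `Cc1cccc(C(=O)Nn2c(CC3CCCCC3)nc3c(-c4ccc(Cl)cc4)n[nH]c3c2=O)c1`: 88.7%
- compound 3 `CC(C)(C)c1ccc(C(=O)Nn2c(CC3CCCCC3)nc3c(-c4ccc(Cl)cc4)n[nH]c3c2=O)cc1`: 72.4%

In a functional assay on HT-29 cells (Homo sapiens) for cytotoxicity, read by sulforhodamine B assay, with a stated time of 2 days, tested at 100 uM (on this read-out lower numbers stand for less inhibition and higher numbers for more inhibition at the one concentration tested (going by the name of the read-out)), compound 3 gives the lowest of the three numbers: compound 1 sits higher, and compound 2 higher still, both gaps beyond the scatter. Among the measured compounds shown here, the one step that reaches compound 3, a number 16.3 percentage points lower from compound 2 to compound 3 (beyond the scatter), changed the acyl group, not the chain. Compound 4 `CC(C)(C)c1ccc(C(=O)Nn2c(CCC3CCCC3)nc3c(-c4ccc(Cl)cc4)n[nH]c3c2=O)cc1` differs from compound 3 by cyclopentylmethyl in place of cyclohexyl on a saturated chain carbon bound to an aromatic carbon. For the measured compounds named here, no measured step isolates this chain change; compound 1 and compound 2 carry the two chains but also different acyl groups, so their values cannot be separated into a chain effect. The expected step of a number 2.6 percentage points higher from compound 3 to compound 4 (within the scatter) is therefore none beyond the scatter, and compound 4 is estimated at 75% with a range from 60% to 88%.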

Compound 4, a percentage reported as inhibition, at one concentration (the size of the read-out at that concentration, not a potency): 76.8%
The estimate for compound 4 lay 1.8 percentage points below the measured number, and the stated range covers the measured number.
By their numbers in this assay, from the lowest: compounds 3 and 4 (each within the scatter of the next); then compounds 1 and 2 (each within the scatter of the next).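

In this assay, the chain change alone gives a number 4.4 percentage points higher from compound 3 to compound 4 (within the scatter), so with the tert-butyl acyl group in place, cyclopentylmethyl and cyclohexyl on that saturated chain carbon cannot be told apart. Among the compounds shown here, with the 2-cyclopentylethyl chain held fixed, tert-butyl in place of hydrogen on an aromatic carbon gives a number 10.5 percentage points lower from compound 1 to compound 4 (beyond the scatter), the first reading of that acyl change on this chain. Nothing available explains either step.

As far as these compounds go, it remains open whether an amine or a carboxylic acid in place of tert-butyl would move the number, and whether a longer chain would.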